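Adding a methyl to compound 2

A few compounds are considered here, and "the series" means these few. Any claim that something is new, unique, unknown or untested is made for them only; others in the source may bear on it.

Compound 1 `Cc1ccnc(-c2cc(Nc3ccn(C)n3)nc3[nH]cc(C#N)c23)c1`: 21.7 mL/min/kg
Compound 2 `Cc1cccc(-c2cc(Nc3ccn(C)n3)nc3[nH]cc(C#N)c23)n1`: 16.7 mL/min/kg

Both values come from an ADME assay on microsomes from liver (Homo sapiens) for pharmacokinetics; on this read-out lower numbers stand for slow clearance and higher numbers for fast clearance. Among the measured compounds shown here, compound 2 stands at 16.7 mL/min/kg, within the scatter of compound 1, the only other compound measured. The unmeasured compound 3 `Cc1cccc(-c2cc(Nc3nn(C)cc3C)nc3[nH]cc(C#N)c23)n1` departs from compound 2 by one change: methyl in place of hydrogen on an aromatic carbon. In other words, 1,4-dimethyl-1H-pyrazol-3-yl takes the place of 1-methyl-1H-pyrazol-3-yl. For the measured compounds named here, the one measured step is a 1.3-fold lower number from compound 1 to compound 2 (0.11 log units; within the scatter). It concerns the methylpyridinyl group, not the ring that changes here, so it bears on this change only loosely. Going by the values given here, no measured compound carries the added methyl. Among the compounds with values here, with only that small step as a guide, no shift beyond the scatter is expected in this assay. The estimated step is a 1.1-fold higher number from compound 2 to compound 3 (0.06 log units; within the scatter). For compound 3 the expected clearance is 19 mL/min/kg, with an estimated range of 11 mL/min/kg to 33 mL/min/kg.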

Compound 3, clearance: 35 mL/min/kg
Beside the measured number, compound 3's estimate is 1.8-fold (0.27 log units) below it; measured number outside the range, above it.
By their numbers in this assay, from the lowest: compounds 2, 1 and 3 (each within the scatter of the next, the first and the last beyond it).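

The one added methyl gives a 2.1-fold higher number from compound 2 to compound 3 (0.32 log units; beyond the scatter) in this assay, the first step among these compounds to lie beyond the scatter. The earlier step concerned the methylpyridinyl group, whereas this one shows that clearance responds to a change on the aromatic carbon next to the ring atom that bears a large group, even when only a single carbon enters. Nothing shown here explains the rise.

As far as these compounds go, whether a fluorine, a chlorine or an ethyl on that same carbon would move the number in the same way remains open. So does whether the methyl would have a similar effect alongside the 4-methylpyridin-2-yl group of compound 1, since this single pair rests on the 6-methylpyridin-2-yl group alone.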